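Lengthening the Chain from Compound 3 to Compound 4

The source may hold more compounds than are shown below. What is called first, only, known or untested is meant among the compounds shown, and "the series" means these compounds.

Measured in a functional assay on MGC-803 cells (Homo sapiens) for antiproliferative activity, read by MTT assay, with a stated time of 48 h; a higher number here means a weaker inhibitor, a lower number a stronger inhibitor:
- Compound 1 `CCCCCCCCCn1cc(COC[C@@H]2OC[C@H](N)[C@@H]2O)nn1`: 13800 nM
- Compound 2 `CCCCCCCCCCn1cc(COC[C@@H]2OC[C@H](N)[C@@H]2O)nn1`: 8780 nM
- Compound 3 `CCCCCCCCCCCCCCn1cc(COC[C@@H]2OC[C@H](N)[C@@H]2O)nn1`: 8210 nM

Compound 3 does not stand apart from the other two compounds, since all three values lie within the usual scatter of one another. The change to compound 4 `CCCCCCCCCCCCCCCCCCn1cc(COC[C@@H]2OC[C@H](N)[C@@H]2O)nn1` is butyl in place of hydrogen on a saturated chain carbon, ten or more bonds along the chain from an aromatic nitrogen. The same butyl addition appeared earlier as a 1.1-fold lower number from compound 2 to compound 3 (0.03 log units; within the scatter). The other chain extensions gave a 1.6-fold lower number from compound 1 to compound 2 (0.20 log units; within the scatter) and a 1.7-fold lower number from compound 1 to compound 3 (0.23 log units; within the scatter). Going by the values given here, none of these steps leaves the scatter, so no step beyond it is expected in this assay, although no measured compound carries a chain as long as this one. The expected step is a 1.1-fold higher number from compound 3 to compound 4 (0.04 log units; within the scatter). Compound 4 is estimated at 9000 nM, with an expected range of 4000 nM to 22000 nM.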

Compound 4, half-maximal inhibitory concentration: 15400 nM
Estimate against measurement, compound 4: 1.7-fold (0.23 log units) below; the range from low to high includes it.
By their numbers in this assay, from the lowest: compounds 3, 2, 1 and 4 (each within the scatter of the next).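

Even the longest chain shown does not move the result out of the scatter in this assay: this butyl addition gives a 1.9-fold higher number from compound 3 to compound 4 (0.27 log units; within the scatter), octyl gives a 1.8-fold higher number from compound 2 to compound 4 (0.24 log units; within the scatter), and nonyl gives a 1.1-fold higher number from compound 1 to compound 4 (0.05 log units; within the scatter). Across these four compounds, then, chain length at this position shows no clear effect on the measured number. Nothing available explains these values. Still open, as far as these compounds go, is whether a much shorter chain would give a step beyond the scatter. The same question stands for an amine or a carboxylic acid carried on the chain.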